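The source may report more compounds than this note shows. Statements on the series, on what has been measured and on what is new or still open speak of the compounds shown alone.

Compound 1 `CC(C)C(c1ncc[nH]1)c1ccc(-c2ccc3cccc(F)c3c2)[nH]c1=O` is the starting point. In a physicochemical assay for solubility, in phosphate buffer, measured as kinetic solubility (a higher number here means a more soluble compound, a lower number a less soluble compound), compound 1 gives 20600 nM, the lowest of the three numbers, with compound 3 `CC(C)C(c1ccc(-c2ccc3cccc(F)c3c2)[nH]c1=O)N1CCCCC1=O` at 23100 nM as the nearest and compound 2 `CC(C)C(c1nnc[nH]1)c1ccc(-c2ccc3cccc(F)c3c2)[nH]c1=O` at 24500 nM as the furthest, both within the scatter of compound 1. Compound 4 `CC(C)C(c1ccc(-c2ccc3cccc(F)c3c2)[nH]c1=O)N1CCNC1=O` carries the change (2-oxoimidazolidin-1-yl in place of 1H-imidazol-2-yl on a saturated chain carbon bound to an aromatic carbon and a saturated chain carbon). Two measured steps alter the same place on the core of compound 1: a 1.2-fold higher number from compound 1 to compound 2 (0.08 log units; within the scatter) and a 1.1-fold higher number from compound 1 to compound 3 (0.05 log units; within the scatter). Both bear on the new change, and neither lies beyond the scatter. The expected step in this assay is therefore a 1.1-fold higher number from compound 1 to compound 4 (0.05 log units; within the scatter), none beyond the scatter. Compound 4 is estimated at 23000 nM, with a range from 12000 nM to 45000 nM.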

Compound 4, solubility: 24900 nM
Compound 4: the middle estimate sits 1.1-fold (0.03 log units) below what was measured; the measured number falls inside the stated range.
By their numbers in this assay, from the lowest: compounds 1, 3, 2 and 4 (each within the scatter of the next).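

In this assay, 2-oxoimidazolidin-1-yl on this saturated chain carbon stays within the scatter of all three earlier groups (a 1.2-fold higher number from compound 1 to compound 4 (0.08 log units; within the scatter)), (a 1.1-fold higher number from compound 3 to compound 4 (0.03 log units; within the scatter)) and (a 1.0-fold higher number from compound 2 to compound 4 (0.01 log units; within the scatter)). With compound 4, a five-membered non-aromatic ring joins the five-membered aromatic rings and 2-oxopiperidin-1-yl, and no two of these four compounds lie beyond the scatter of each other. No supporting measurement bears on this result. As far as these compounds go, whether an open-chain amine or a carboxylic acid at this place would move the number beyond the scatter remains open.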